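Swapping an amino acid arm for a small amide

This account rests on a few compounds, and the source may have more. Where it says the series, first, only, none or still open, it means among the compounds named here.

Measured so far:
compound 1 `O=C1NCc2c(NCc3ccccc3[N+](=O)[O-])cccc21`: 29%
compound 2 `O=C(O)CNc1cccc(CNc2cc(C(F)(F)F)cc3[nH]ncc23)c1`: 65%

Both compounds were tested in an assay for inhibition of Tryptophan 2,3-dioxygenase (Homo sapiens), with stated times of 10 min and 60 min, tested at 100 uM; on this read-out higher numbers stand for a stronger effect at the one concentration tested and lower numbers for a weaker effect. Compound 2 gives the higher of the two numbers, and its gap to compound 1 lies beyond the usual scatter of repeated runs, so compound 2 is the stronger of the pair on this read-out. The next compound, compound 3 `CNC(=O)c1cccc(CNc2cc(C(F)(F)F)cc3[nH]ncc23)c1`, keeps the core of compound 2 and alters a single group: methylcarbamoyl in place of (carboxymethyl)amino on an aromatic carbon. Among the compounds with values here, no measured pair of compounds shows the effect of exactly this exchange, so nothing in the data fixes the direction of the step. With no guide either way, the step of a number 10 percentage points lower from compound 2 to compound 3 (within the scatter) is expected to stay within the usual scatter. Compound 3 is therefore estimated to give about 55% in this assay, with a likely range from 25% to 80%.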

Compound 3, a percentage reported as inhibition, at one concentration (the size of the read-out at that concentration, not a potency): 91%
Compound 3: middle estimate off by 36 percentage points, on the low side; measured number above the stated range.
By their numbers in this assay, from the lowest: compound 1; then compound 2; then compound 3.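

On the aromatic carbon that carries this arm, replacing (carboxymethyl)amino with methylcarbamoyl gives a number 26 percentage points higher from compound 2 to compound 3 (beyond the scatter) in this assay, so the read-out responds to the group placed here. The amino acid arm is not required for the effect, as the methylcarbamoyl group has fewer heavy atoms, hydrogen-bond donors and hydrogen-bond acceptors and still gives the higher number on the same core. Nothing measured here explains why the step goes upward.

The compounds shown leave open whether the rise depends on the amide itself or only on the loss of the arm, a question that a carboxylic acid on the ring, a primary amide or a longer chain on the amide nitrogen could help settle. On these data alone, each number is also the size of the effect at one concentration, so the potency gap between these two compounds remains unknown.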